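The compounds below may be only part of what the source reports. "The series", "measured", "known", "first", "only" and "open" are said of these compounds alone.

Compound 1 `COc1ccccc1N1C(=O)C(C)SC1c1cccc(C(=O)NCCCCc2ccccc2)c1` gives 2660 mL.min-1.g-1 in an ADME assay on microsomes from liver (Homo sapiens) for metabolic stability, read by LC-MS, using NADPH, with a stated time of 10 min, tested at 0.1 uM; on this read-out lower numbers stand for slow clearance and higher numbers for fast clearance. Compound 2 `COc1ccc(F)cc1N1C(=O)CSC1c1cccc(C(=O)NCCCCn2cccn2)c1` gives 421 mL.min-1.g-1. Compound 3 `O=C(NCCCCc1ccccc1)c1cccc(C2SCC(=O)N2c2cccc(F)c2)c1` gives 1840 mL.min-1.g-1.

In this assay compound 3 sits close to compound 1, a gap within the usual scatter, and well above compound 2, a gap beyond it. Compound 4 `Cc1cccc(N2C(=O)CSC2c2cccc(C(=O)NCCCCc3ccccc3)c2)c1` is the next compound in line. It differs from compound 3 in one place: methyl in place of fluoro on an aromatic carbon. Among the compounds with values here, no measured pair shows this same change, so the step can only be guessed from the numbers at hand. Both compound 1 and compound 3 clear fast, and a single-atom swap of this kind is expected to move the read-out little, so the step from compound 3 to compound 4 is expected to be a 1.3-fold higher number from compound 3 to compound 4 (0.10 log units; within the scatter), not beyond the scatter. Compound 4 is therefore estimated at 2300 mL.min-1.g-1, in a range from 1100 mL.min-1.g-1 to 4800 mL.min-1.g-1.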

Compound 4, intrinsic clearance in microsomes: 2550 mL.min-1.g-1
Beside the measured number, compound 4's estimate is 1.1-fold (0.04 log units) below it; the range from low to high includes it.
By their numbers in this assay, from the lowest: compound 2; then compounds 3, 4 and 1 (each within the scatter of the next).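

In this assay, within the data shown here, methyl in place of fluoro on the aromatic carbon meta to a large group gives a 1.4-fold higher number from compound 3 to compound 4 (0.14 log units; within the scatter) as the first step between measured compounds that differ in one place. At this position, 3-fluorophenyl and 3-methylphenyl therefore cannot be told apart on this read-out, and both compounds remain in the same range of numbers. Nothing at hand explains why these two groups read alike. As far as these compounds go, whether an amine or a carboxylic acid at this position would shift the clearance remains open. So does whether the same change would read alike with the side chain of compound 2.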